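Fluoro to Hydrogen on the Benzyl Group, Across Two Cores

A few compounds are considered here, and "the series" means these few. Any claim that something is new, unique, unknown or untested is made for them only; others in the source may bear on it.

Compound 1 `O=C(CC1c2ccccc2N=C(SCCCCCN2CCCC2)N1c1ccc(-c2ccccc2)cc1)NCc1ccc(F)cc1` was tested in a functional assay on A549 cells (Homo sapiens) for cytotoxicity, read by MTT assay, with a stated time of 48 h (a higher number here means a weaker inhibitor, a lower number a stronger inhibitor), where compound 1 gives 19800 nM. Compound 3 `O=C(CC1c2ccccc2N=C(SCCCCCN2CCCC2)N1c1ccc(-c2ccccc2)cc1)NCc1ccccc1` differs from it by a single change, (hydrogen in place of fluoro on an aromatic carbon), and in this assay compound 3 gives 14900 nM. The step that this change made is a 1.3-fold lower number from compound 1 to compound 3 (0.12 log units; within the scatter), so the fluoro and the hydrogen analogue on this core cannot be told apart by this measurement.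

Compound 2 `CN(C)CCCCCSC1=Nc2ccccc2C(CC(=O)NCc2ccc(F)cc2)N1c1ccccc1` carries a different core; the difference between the two cores is not broken down here. In this assay compound 2 gives 36800 nM. Its number sits within the scatter of that of compound 1, while the gap from compound 2 to compound 3 lies beyond the scatter, so compound 3 reads lower than compound 2 even though the two steps that connect them cannot be separated one by one.

Compound 4 `CN(C)CCCCCSC1=Nc2ccccc2C(CC(=O)NCc2ccccc2)N1c1ccccc1` stands to compound 2 as compound 3 stands to compound 1: the change is hydrogen in place of fluoro on an aromatic carbon, and the place is described in the same words for both pairs, so it is the same change on another core. Within the data shown here, its only measured precedent is the step from compound 1 to compound 3, which lies within the scatter. Among the measured compounds shown here, the author therefore expects the step of a 1.3-fold lower number from compound 2 to compound 4 (0.12 log units; within the scatter) to be small, resting on a 1.3-fold lower number from compound 1 to compound 3 (0.12 log units; within the scatter) as the sole precedent, with the other core as the main source of uncertainty. For compound 4 the estimate in this assay is 28000 nM, expected to fall between 14000 nM and 56000 nM.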

Compound 4, half-maximal inhibitory concentration: 138000 nM
Estimate against measurement, compound 4: 4.9-fold (0.69 log units) below; measured number above the stated range.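

In this assay, hydrogen in place of fluoro on the benzyl group gives a 3.8-fold higher number from compound 2 to compound 4 (0.57 log units; beyond the scatter), a step that can be told from the scatter, unlike the step on the other core. Set side by side, the two steps do not agree: the same change on two cores in this assay, a 1.3-fold lower number (0.12 log units; within the scatter) from compound 1 to compound 3 and a 3.8-fold higher number (0.57 log units; beyond the scatter) from compound 2 to compound 4, 5.0-fold (0.70 log units) apart, beyond the scatter of two such steps. This shows that, for these two cores, the result of the change on the core of compound 1 could not be carried over to the core of compound 2, so a single pair is a poor guide to this change elsewhere in the series; it does not show which feature of the cores sets the two steps apart, how the change would read on a third core, or what the step would be in any other assay.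

The compounds shown leave open whether a chloro or a methoxy group on the benzyl group, in the place of the fluoro, would also read differently on the two cores. They also leave open which part of the two cores matters, the aromatic group on the ring nitrogen or the amine at the end of the chain, as no compound shown combines the one from compound 1 with the other from compound 2.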